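This account rests on a few compounds, and the source may have more. Where it says the series, first, only, none or still open, it means among the compounds named here.

Two esters built on the same core have been tested for cytotoxicity. Compound 1 `CCCC(=O)OCCc1c(-c2ccccc2Cl)c2cc(Cl)ccc2[nH]c1=O` carries a propyl chain on its carbonyl carbon, and in an ADME assay on HepG2 2.2.15 cells (Homo sapiens) for cytotoxicity (on this read-out lower numbers stand for higher toxicity in this test and higher numbers for lower toxicity in this test), compound 1 gives 52000 nM. Compound 2 `O=C(OCCc1c(-c2ccccc2Cl)c2cc(Cl)ccc2[nH]c1=O)c1ccccc1` carries a phenyl ring in place of that propyl chain; in this assay compound 2 gives 43000 nM. The step of a 1.2-fold lower number from compound 1 to compound 2 (0.08 log units; within the scatter) shows that this swap hardly moved the number. Of the two numbers recorded, compound 2 has the smaller, but compound 1 lies within the scatter of it, so the two compounds cannot be told apart on toxicity.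

Compound 3 `O=C(/C=C/c1ccccc1)OCCc1c(-c2ccccc2Cl)c2cc(Cl)ccc2[nH]c1=O` differs from compound 2 by a single change, (2-phenylethenyl in place of phenyl on a carbonyl carbon). Among the measured compounds shown here, the only measured step that bears on it is a 1.2-fold lower number from compound 1 to compound 2 (0.08 log units; within the scatter), which also exchanged the carbon group on the carbonyl carbon and stayed within the scatter. For the measured compounds named here, no measured step speaks to inserting a double bond into that group. The expected step of a 1.1-fold lower number from compound 2 to compound 3 (0.05 log units; within the scatter) in this assay is therefore none beyond the scatter. Compound 3 is estimated at 38000 nM, with a range from 18000 nM to 80000 nM.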

Compound 3, half-maximal cytotoxic concentration: 230000 nM
Estimate against measurement, compound 3: 6.1-fold (0.78 log units) below, outside the stated range (above it).
By their numbers in this assay, from the lowest: compounds 2 and 1 (each within the scatter of the next); then compound 3.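

In this assay, the group on the carbonyl carbon turns out not to be indifferent. The change to 2-phenylethenyl gives a 5.3-fold higher number from compound 2 to compound 3 (0.73 log units; beyond the scatter) and a 4.4-fold higher number from compound 1 to compound 3 (0.65 log units; beyond the scatter), both beyond the scatter, whereas the earlier exchange of propyl for phenyl left the two compounds indistinguishable. On this read-out a higher number stands for lower toxicity in this test, so among these three esters the 2-phenylethenyl group is the one that stands apart from the other two, though only modestly, and nothing measured here gives a reason for that difference.

The compounds shown leave open which feature of 2-phenylethenyl goes with the higher number: the double bond outside the aromatic ring, or simply the extra carbon atoms that set the ring further from the carbonyl carbon, and a saturated 2-phenylethyl group on the same carbonyl carbon would separate the two. Going by these compounds, it also remains open whether the number would hold with a fluorine or a methoxy group on the phenyl ring of the 2-phenylethenyl group, or with a simple ethenyl group with no ring at all.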